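A Fluorine Added to Two Related Ketones

The source may report more compounds than this note shows. Statements on the series, on what has been measured and on what is new or still open speak of the compounds shown alone.

Compound 1 `O=C1/C(=C/c2ccccc2)CCc2ccccc21` and compound 3 `O=C1CCCCC/C1=C\c1ccccc1` are built on different cores; the difference between the two cores is not broken down here. In a functional assay on CCRF-CEM cells (Homo sapiens) for inhibition (on this read-out lower numbers stand for stronger inhibition and higher numbers for weaker inhibition), compound 1 gives 7420 nM, while compound 3 gives 110000 nM. Compound 2 `O=C1/C(=C/c2ccc(F)cc2)CCc2ccccc21` carries fluoro in place of hydrogen on an aromatic carbon on the core of compound 1; in this assay compound 2 gives 33400 nM, which is a 4.5-fold higher number from compound 1 to compound 2 (0.65 log units; beyond the scatter). Compound 4 `O=C1CCCCC/C1=C\c1cccc(F)c1` carries fluoro in place of hydrogen on an aromatic carbon on the core of compound 3. This is the same kind of change, not the same one: in compound 2 the fluoro sits para to a large group, in compound 4 meta to a group of 9 heavy atoms. The expected size of the new step rests on the earlier one, a 4.5-fold higher number from compound 1 to compound 2 (0.65 log units; beyond the scatter), with extra uncertainty for the changed place. Compound 4 is therefore expected to show a 2.3-fold higher number from compound 3 to compound 4 (0.36 log units; beyond the scatter) and to give about 250000 nM, between 80000 nM and 700000 nM.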

Compound 4, half-maximal inhibitory concentration: 224000 nM
Compound 4: the middle estimate sits 1.1-fold (0.05 log units) above what was measured; low and high end bracket the measured number.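

Fluoro in place of hydrogen on an aromatic carbon gives a 2.0-fold higher number from compound 3 to compound 4 (0.31 log units; beyond the scatter) in this assay as well, so inhibition becomes weaker on this core too. The change therefore goes the same way on both cores, and the two step sizes cannot be told apart: the same change on two cores in this assay, a 4.5-fold higher number (0.65 log units; beyond the scatter) from compound 1 to compound 2 and a 2.0-fold higher number (0.31 log units; beyond the scatter) from compound 3 to compound 4, 2.2-fold (0.34 log units) apart, within the scatter of two such steps. Within the data shown here, this does not set a general rule, as it rests on only two pairs, and the fluoro sits at a different place in each, so the effect of the core is not separated from that of the place.

Still open, as far as these compounds go, is how fluoro would behave at the same place on both cores. Also open, from the compounds shown here alone, is whether a different group on the ring, such as an amine or a carboxylic acid, would shift the number in the same direction.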